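Swapping Dichlorophenyl for Dimethylphenyl on the Amide Nitrogen

The compounds below may be only part of what the source reports. "The series", "measured", "known", "first", "only" and "open" are said of these compounds alone.

Of the compounds shown here, three have so far been measured in a functional assay on HEK293 cells for agonist activity at D(4) dopamine receptor (Homo sapiens), read by FLIPR; a lower number here means a smaller maximal response, a higher number a larger maximal response. Compound 2 `O=C(CN1CCC(c2cccc[n+]2[O-])CC1)Nc1cc(Cl)cc(Cl)c1` gives 68%, the highest number of the three. Compound 3 `O=C(NCN1CCC(c2cccc[n+]2[O-])CC1)c1ccc2ccccc2c1` gives 67%, which lies within the usual scatter of compound 2. Compound 1 `O=C(CN1CCC(c2ccccn2)CC1)Nc1c(Cl)cc(Cl)cc1Cl` gives 45%, clearly below compound 2. Compound 4 `Cc1cccc(C)c1NC(=O)CN1CCC(c2cccc[n+]2[O-])CC1` has not yet been measured. It differs from compound 2 in a single place: 2,6-dimethylphenyl in place of 3,5-dichlorophenyl on an amide-type nitrogen. For the measured compounds named here, no measured pair shows this exact change, so its effect is unknown. A moderate drop is expected rather than a rise, because compound 1 with a differently substituted phenyl gives only 45%. Compound 4 is therefore estimated at 50%, between 30% and 72%. The expected step is a number 18 percentage points lower from compound 2 to compound 4 (beyond the scatter).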

Compound 4, largest response reached (reported as efficacy), in percent of the reference or control that the assay uses: 68%
Estimate against measurement, compound 4: 18 percentage points below, within the range that was stated.
By their numbers in this assay, from the lowest: compound 1; then compounds 3, 2 and 4 (each within the scatter of the next).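

On the amide-type nitrogen, replacing 3,5-dichlorophenyl with 2,6-dimethylphenyl gives no change at the digits printed from compound 2 to compound 4 (within the scatter) in this assay. For the compounds shown here, this is the first direct reading at this place: both chlorine atoms can leave, and two methyl groups can enter, without a measurable loss of maximal response. Nothing measured here explains why the two groups match.

As far as these compounds go, it remains open whether this tolerance extends beyond these two carbon-only aromatic groups. A phenyl ring carrying a carboxylic acid or an amine, or a longer alkyl chain in place of the ring, could test that.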